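This account rests on a few compounds, and the source may have more. Where it says the series, first, only, none or still open, it means among the compounds named here.

Measured so far:
compound 1 `CCCCCCCCCCCOc1ccccc1CCC(=O)OCCCOP(=O)(O)OC[C@H](N)C(=O)O` — 0.04
compound 2 `N[C@@H](COP(=O)(O)OCCCOC(=O)CCc1ccccc1OCCCCOc1ccccc1)C(=O)O` — 0.033
compound 3 `Cc1cccc(Oc2cccc(COc3ccccc3CCC(=O)OCCCOP(=O)(O)OC[C@H](N)C(=O)O)c2)c1` — 0.29

In an assay on cells for activation of probable G-protein coupled receptor 34 (Mus musculus), with a stated time of 1 h (a lower number here means a smaller maximal response, a higher number a larger maximal response), compound 3 gives 0.29 and stands highest of the three; both compound 1 and compound 2 lie below it by more than the scatter, so the diaryl ether tail of compound 3 marks it off from the two with a single-ring tail. Among the measured compounds shown here, the one measured step, a number 0.0070 lower from compound 1 to compound 2 (within the scatter), swaps a chain tail for a ring tail far out on the chain and moves nothing beyond the scatter, so it says little about substituents on the outer ring.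

Compound 4 `N[C@@H](COP(=O)(O)OCCCOC(=O)CCc1ccccc1OCc1cccc(Oc2ccc(Br)cc2)c1)C(=O)O` is to be measured in this assay. It differs from compound 3 as follows: 4-bromophenyl in place of 3-methylphenyl on an oxygen on an aromatic ring. For the measured compounds named here, no measured step touches a substituent on that outer ring, so the change is unanchored; both ends keep the diaryl ether tail that compound 3 carries. The step a number 0.020 lower from compound 3 to compound 4 (within the scatter) is therefore expected to stay within the scatter, in either direction. Compound 4 is estimated at 0.27, with a range from 0.12 to 0.42.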

Compound 4, intrinsic activity: the largest response reached, as a fraction of the reference agonist's: 0.97
Compound 4: the middle estimate sits 0.70 below what was measured; measured number outside the range, above it.
By their numbers in this assay, from the lowest: compounds 2 and 1 (each within the scatter of the next); then compound 3; then compound 4.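

In this assay the aryl group on the outer ether oxygen proves to be far from a silent position: 4-bromophenyl in place of 3-methylphenyl gives a number 0.68 higher from compound 3 to compound 4 (beyond the scatter) even though both groups have the same heavy-atom count, a single six-membered aromatic ring of carbon only, and no hydrogen-bond donors or acceptors. Among the compounds shown here, the only earlier step, from a heptyl to a phenoxy end group on the chain, touched no substituent on this ring and stayed within the scatter, so this is the first sign of sensitivity to the outer ring. Nothing measured here accounts for the size of this step.

The change swaps both the substituent and its ring position, and the compounds shown do not separate the two. 4-Methylphenyl and 3-bromophenyl would separate them, while 4-chlorophenyl would test whether bromine itself is needed.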